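Cyclopropyl on the amide nitrogen: a repeated step

A few compounds are considered here, and "the series" means these few. Any claim that something is new, unique, unknown or untested is made for them only; others in the source may bear on it.

Compound 3 `Cc1cccc2c1CC/C2=C\C(N)=O` and compound 1 `Cc1cccc2c1CC/C2=C\C(=O)NC1CC1` share a core and differ by cyclopropyl in place of hydrogen on an amide-type nitrogen. In a functional assay on the whole organism with Rattus norvegicus as the target, at a dose of 20 mg/kg by the oral route (a lower number here means less inhibition, a higher number more inhibition at the dose given (going by the name of the read-out)), compound 3 gives 13% and compound 1 gives 7%; the change made a number 6 percentage points lower from compound 3 to compound 1 (within the scatter). Compound 2 `NC(=O)/C=C1\CCc2ccc(Br)cc21` gives 21% in this assay; the difference between its core and the core of compound 3 is not broken down here. Compound 4 `O=C(/C=C1\CCc2ccc(Br)cc21)NC1CC1` is not yet measured and differs from compound 2 by cyclopropyl in place of hydrogen on an amide-type nitrogen, the same change as between compound 3 and compound 1. On the strength of that earlier step, a number 6 percentage points lower from compound 2 to compound 4 (within the scatter) is expected, a step of similar size. Compound 4 is therefore estimated at 15% in this assay, between 4% and 27%.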

Compound 4, a percentage reported as inhibition, in the whole organism at one dose (the size of the read-out at that dose, not a potency): 4%
Beside the measured number, compound 4's estimate is 11 percentage points above it; low and high end bracket the measured number.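

On the core of compound 2, cyclopropyl in place of hydrogen on the amide-type nitrogen gives a number 17 percentage points lower from compound 2 to compound 4 (beyond the scatter). Set beside the step on the other core, this gives no sign in this assay that the change behaves differently from one core to the other: the same change on two cores in this assay, a number 6 percentage points lower (within the scatter) from compound 3 to compound 1 and a number 17 percentage points lower (beyond the scatter) from compound 2 to compound 4, 11 percentage points apart, within the scatter of two such steps Only one of the two steps lies beyond the scatter, so this pair of cores does not fix a common step size and shows nothing about the change on any further core.

The amide nitrogen carries only hydrogen or cyclopropyl in the compounds shown. Going by these compounds, whether a methyl group, a longer chain or a larger ring such as cyclohexyl would give a similar number remains open.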